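Adding a sulfonyl group to compound 3

The source may report more compounds than this note shows. Statements on the series, on what has been measured and on what is new or still open speak of the compounds shown alone.

In a functional assay on QGY-7703 cells (Homo sapiens) for cytotoxicity, read by MTT assay, with a stated time of 24 h (a higher number here means a weaker inhibitor, a lower number a stronger inhibitor), compound 1 (`COc1cc(/C=C2\CN(C)C/C(=C\c3cccnc3)C2=O)cc(OC)c1OC`) gives 4300 nM and compound 2 (`COc1ccc(/C=C2\CN(C)C/C(=C\c3ccncc3)C2=O)c(OC)c1OC`) gives 8350 nM as measured. Compound 3 (`O=C1/C(=C/c2cccnc2)CNC/C1=C\c1ccccc1F`) gives 8890 nM and lies within the scatter of compound 2 but beyond the scatter of compound 1, which has the lower number. Compound 4 (`O=C1/C(=C/c2cccnc2)CN(S(=O)(=O)c2ccc(Br)cc2)C/C1=C\c1ccccc1F`) has (4-bromophenyl)sulfonyl in place of hydrogen on an amine nitrogen in a ring and remains unmeasured. Going by the values given here, no measured pair shows this kind of change, so the size of the step is a judgement. In this assay a moderate move toward a stronger inhibitor is expected, with a 3.0-fold lower number from compound 3 to compound 4 (0.47 log units; beyond the scatter) as the estimated step for now. Compound 4 is estimated at 3000 nM with 800 nM and 10000 nM as the ends of the expected range.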

Compound 4, half-maximal inhibitory concentration: 12800 nM
Compound 4: middle estimate off by 4.3-fold (0.63 log units), on the low side; measured number above the stated range.
By their numbers in this assay, from the lowest: compounds 1, 2, 3 and 4 (each within the scatter of the next, the first and the last beyond it).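

In this assay, (4-bromophenyl)sulfonyl in place of hydrogen on the amine nitrogen in the ring gives a 1.4-fold higher number from compound 3 to compound 4 (0.16 log units; within the scatter). This first one-place step in the series shows that this ring nitrogen accepts a substituent of 10 heavy atoms with no reading beyond the scatter. Nothing at hand bears on why compound 3 and compound 4 read alike.

Going by these compounds, whether an acetyl or methylsulfonyl group on this nitrogen would separate from compound 3 remains open. So does the part played by the bromine, which a plain phenylsulfonyl group would test.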